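This account rests on a few compounds, and the source may have more. Where it says the series, first, only, none or still open, it means among the compounds named here.

Measured so far in a toxicity assay on THP-1 cells (Homo sapiens) for inhibition; a lower number here means that less compound is tolerated, a higher number that more compound is tolerated:
- Compound 1 `Cc1cccc(-c2cnc(NC(=O)c3ccc(F)cc3)n2C)c1`: > 100000 nM (a limit)
- Compound 2 `Cn1c(-c2cccc([N+](=O)[O-])c2)cnc1NC(=O)c1ccc(F)cc1`: > 50000 nM (a limit)
- Compound 3 `COc1ccc(-c2cnc(NC(=O)c3ccc(F)cc3)n2C)cc1`: >= 50000 nM (a limit)

Compound 3 stands at >= 50000 nM, which is a limit of the assay and not a number. For the measured compounds named here, the other two values are limits as well, so no compound in this set has yet given a true number in this assay.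

Compound 4 `Cn1c(-c2cccc(Br)c2)cnc1NC(=O)c1ccc(F)cc1` carries 3-bromophenyl in place of 4-methoxyphenyl on an aromatic carbon.

Going by the values given here, two measured steps bear on this change, since both alter the aromatic group on the shared core: a step that the two limits leave unreadable from compound 1 to compound 2 and a step that the two limits leave unreadable from compound 1 to compound 3. Neither has a readable size. Among the compounds with values here, they show only that the three aromatic groups tried so far all ended in a limit. Compound 1, with its 3-methylphenyl group, gives > 100000 nM. Compound 2, with its nitro group in place of that methyl, gives > 50000 nM.

On this basis, no step beyond the scatter is expected in this assay, and no direction can be assigned. The expected change is a number no higher from compound 3 to compound 4 (the limit leaves the size open). For compound 4 the estimated value is 50000 nM, with an expected range of 20000 nM to 100000 nM.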

Compound 4, half-maximal cytotoxic concentration: > 50000 nM
Compound 4 ended at the assay's limit (the forecaster's own chance of this, stated with the estimate: 75%); the middle value sits exactly at the limit.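

In this assay compound 4 gives > 50000 nM, which is a limit of the assay and not a number. The steps to compound 4 from compound 1, compound 2 and compound 3 cannot be read, as all four values are limits. The compounds shown leave open whether these four differ at all in half-maximal cytotoxic concentration, and what any true value would be.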